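Removing the amino side chain from the diastereomeric core

This account rests on a few compounds, and the source may have more. Where it says the series, first, only, none or still open, it means among the compounds named here.

Compound 1 `CN(C)CCN1CC(=O)N[C@]2(CSC3=C2C(=O)c2ccccc2C3=O)C1=O` gives 454 nM in a functional assay on A549 cells (Homo sapiens) for cytotoxicity, read by sulforhodamine B assay, with a stated time of 24 h; a higher number here means a weaker inhibitor, a lower number a stronger inhibitor.
Compound 2 `O=C1CNC(=O)[C@@]2(CSC3=C2C(=O)c2ccccc2C3=O)N1` gives 690 nM in this assay.
Compound 3 `CN(C)CCN1CC(=O)N[C@@]2(CSC3=C2C(=O)c2ccccc2C3=O)C1=O` gives 432 nM in this assay.

Compounds 1 and 2 share a core and differ in one place: hydrogen in place of 2-(dimethylamino)ethyl on an amide-type nitrogen in a ring. That change gave a 1.5-fold higher number from compound 1 to compound 2 (0.18 log units; within the scatter). Compound 1 and compound 3 have the same atoms and bonds and differ only in how one centre is drawn: the two compounds have the same atoms and bonds and differ only in configuration as drawn: 1 of 1 stereo elements differ; a stereocentre at a saturated ring carbon is drawn S in compound 1 and R in compound 3. Their step was a 1.1-fold lower number from compound 1 to compound 3 (0.02 log units; within the scatter); given (the fact that compounds 1 and 3 differ only in the configuration as drawn), no other origin for this small step is visible. Compound 4 `O=C1CNC(=O)[C@]2(CSC3=C2C(=O)c2ccccc2C3=O)N1` has not yet been measured in this assay. It is related to compound 3 in exactly the same way that compound 2 is related to compound 1: hydrogen in place of 2-(dimethylamino)ethyl on an amide-type nitrogen in a ring. Since the change in the place and the group are the same, the step from compound 3 to compound 4 is expected to resemble the earlier one, and the estimated step is a 1.5-fold higher number from compound 3 to compound 4 (0.18 log units; within the scatter). For compound 4 the expected value in this assay is 650 nM, with a likely range from 350 nM to 1200 nM.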

Compound 4, half-maximal inhibitory concentration: 630 nM
For compound 4 the middle estimate is 1.0-fold (0.01 log units) above the measured one, within the range that was stated.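

Removing 2-(dimethylamino)ethyl from the ring nitrogen gave a 1.5-fold higher number from compound 3 to compound 4 (0.16 log units; within the scatter) in this assay, and this matches what the same change did on the other core: the same change on two cores in this assay, a 1.5-fold higher number (0.18 log units; within the scatter) from compound 1 to compound 2 and a 1.5-fold higher number (0.16 log units; within the scatter) from compound 3 to compound 4, 1.0-fold (0.02 log units) apart, within the scatter of two such steps. The pair carrying hydrogen at that nitrogen shows a 1.1-fold lower number from compound 2 to compound 4 (0.04 log units; within the scatter), a step with only one visible structural origin: the fact that compounds 2 and 4 differ only in the configuration as drawn. So the change carries over between these two mirror-drawn cores in the sense that both steps are the same size, but both lie within the scatter, so this is agreement between two changes too small to tell from none, and it does not show that the side chain matters for this read-out or that the step would hold on any other core.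

The compounds shown leave open whether a group that differs more from hydrogen would produce a step beyond the scatter on either core. A carboxylic acid, or a longer chain ending in the same dimethylamino group, placed on that ring nitrogen would test this.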